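Methoxy for cyano on the benzyl group of compound 3

The source may hold more compounds than are shown below. What is called first, only, known or untested is meant among the compounds shown, and "the series" means these compounds.

The series shares a core carrying a chain that ends in a free acid, and differs in the group on the saturated chain carbon bound to the aromatic nitrogen. In an assay on isolated protein for inhibition of DNA nucleotidylexotransferase (Homo sapiens), read by scintillation counting, with a stated time of 10 min (a lower number here means a stronger inhibitor, a higher number a weaker inhibitor), compound 2 `C=C(C)Cn1cc(/C=C/C(=O)CC(=O)C(=O)O)c2ccccc21` gives 2.5 uM. Compound 3 `N#Cc1ccc(Cn2cc(/C=C/C(=O)CC(=O)C(=O)O)c3ccccc32)cc1` gives 1.4 uM in this assay, the lowest of the two numbers shown, with the step of a 1.8-fold lower number from compound 2 to compound 3 (0.25 log units; within the scatter) being within the scatter. Compound 1 `CCOC(=O)C(=O)CC(=O)/C=C/c1cn(Cc2ccc(OC)cc2)c2ccccc12`, which carries an ethyl ester instead of the acid, reaches only a limit of this assay at > 40 uM.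

Compound 4 `COc1ccc(Cn2cc(/C=C/C(=O)CC(=O)C(=O)O)c3ccccc32)cc1` differs from compound 3 in one place: methoxy in place of cyano on an aromatic carbon. Among the compounds with values here, the only measured step that bears on exchanging the group on that chain carbon is a 1.8-fold lower number from compound 2 to compound 3 (0.25 log units; within the scatter), and it stayed within the scatter. Within the data shown here, no step with the methoxy group on the acid series has been measured. The expected step from compound 3 to compound 4 is therefore a 1.8-fold higher number from compound 3 to compound 4 (0.25 log units; within the scatter), none beyond the scatter. For compound 4 the estimate in this assay is 2.5 uM, between 0.8 uM and 8 uM.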

Compound 4, concentration for 50% inhibition: 10 uM
Estimate against measurement, compound 4: 4.0-fold (0.60 log units) below; the measured number lies above the stated range.
By their numbers in this assay, from the lowest: compounds 3 and 2 (each within the scatter of the next); then compound 4. At a limit, above all of these: compound 1.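

The group on this aromatic carbon turns out to matter: a 7.1-fold higher number from compound 3 to compound 4 (0.85 log units; beyond the scatter) in this assay, whereas the earlier exchange on the chain carbon stayed within the scatter. With 4-methoxyphenyl in place of 1-methylethenyl the result is a 4.0-fold higher number from compound 2 to compound 4 (0.60 log units; beyond the scatter), so the group on that chain carbon does not always leave the number unchanged. The ester and the acid can now be compared with the 4-methoxybenzyl group held constant, giving an at least 4.0-fold lower number from compound 1 to compound 4 (0.60 log units; beyond the scatter), which is only a bound since compound 1 sits at a limit: the limit of > 40 uM in this assay, at which 1 of the 4 values shown sits.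

From the compounds shown here alone, whether a chlorine, a fluorine or a trifluoromethyl group on that aromatic carbon would fall nearer compound 3 or compound 4 remains open. Also open, going by these compounds, is how an unsubstituted benzyl group would compare, and whether an ethyl ester of compound 3 would also reach the limit.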